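The compounds below may be only part of what the source reports. "The series", "measured", "known", "first", "only" and "open" are said of these compounds alone.

Compound 1 `Cc1ccc(-c2nc(CN3CCCC3)nn2C)cc1` sits at the limit of the assay in an assay on membranes from Jurkat cells for displacement of a labelled ligand from Sigma intracellular receptor 2 (Homo sapiens), read by scintillation counting, with a stated time of 1 h (on this read-out lower numbers stand for stronger inhibition and higher numbers for weaker inhibition), with > 1000 nM.
Compound 2 `Cc1cc(-c2nc(CN3CCCC3)nn2C)ccc1C(F)(F)F` also sits at a limit in this assay, with > 1000 nM.
Compound 3 `Cn1nc(CN2CCCC2)nc1-c1ccc(C(F)(F)F)cc1` likewise sits at a limit in this assay, with > 1000 nM.

Compound 2 therefore stands only at a limit, not at a number, as the limit of > 1000 nM in this assay, at which 3 of the 3 values shown sit, shows. The change methyl in place of trifluoromethyl on an aromatic carbon leads to compound 4 `Cc1ccc(-c2nc(CN3CCCC3)nn2C)cc1C`. Within the data shown here, the steps that bear on it, a step that the two limits leave unreadable from compound 2 to compound 3 and a step that the two limits leave unreadable from compound 1 to compound 3, both run between limits and carry no readable size. Among the measured compounds shown here, no measured step here gives a direction, so compound 4 is expected to remain near the limit as well. Compound 4 is estimated at 2000 nM, with a range from 600 nM to 8000 nM. The step that the limit leaves unreadable from compound 2 to compound 4 is an expectation only.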

Compound 4, inhibition constant: > 1000 nM
Compound 4: a limit, no number; the forecaster's own chance of this, stated with the estimate: 75%; the middle value lies beyond the limit too.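

Compound 4 gives only a limit, not a number, in this assay, so its steps from compound 2 and from compound 1 cannot be read. The compounds shown leave open where any of them actually stands, and whether any of these aromatic substitutions changes the value.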